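The source may hold more compounds than are shown below. What is called first, only, known or untested is meant among the compounds shown, and "the series" means these compounds.

Measured compounds in a functional assay on HepG2 cells (Homo sapiens) for inhibition, read by MTT assay, with a stated time of 48 h; a higher number here means a weaker inhibitor of growth, a lower number a stronger inhibitor of growth:
compound 1 `Cn1cc(C2CC(c3ccccc3)=NN2C(=O)c2cccnc2)c2cc(Br)ccc21`: 2520 nM
compound 2 `Cn1cc(C2CC(c3ccc(F)cc3)=NN2C(=O)c2cccnc2)c2cc(Br)ccc21`: 480 nM
compound 3 `COc1ccc2c(c1)c(C1CC(c3ccccc3)=NN1C(=O)c1ccc(OC)nc1)cn2C`: 1330 nM

For the measured compounds named here, the change from compound 1 to compound 2, (fluoro in place of hydrogen on an aromatic carbon), gave a 5.3-fold lower number from compound 1 to compound 2 (0.72 log units; beyond the scatter) in this assay; this is the only example of the change among the measured compounds. Compound 4 `COc1ccc2c(c1)c(C1CC(c3ccc(F)cc3)=NN1C(=O)c1ccc(OC)nc1)cn2C` carries the same change on the core of compound 3: fluoro in place of hydrogen on an aromatic carbon, at the same place. How the core of compound 3 differs from the core of compound 1 is not broken down here. Going by the values given here, for compound 4 in this assay the expected step is a 3.0-fold lower number from compound 3 to compound 4 (0.47 log units; beyond the scatter), in the same direction as the earlier step but taken somewhat smaller, as it rests on the single step of a 5.3-fold lower number from compound 1 to compound 2 (0.72 log units; beyond the scatter) seen on a different core. The estimate for compound 4 is therefore 450 nM, with a likely range from 200 nM to 1100 nM.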

Compound 4, concentration for 50% growth inhibition: 220 nM
For compound 4 the middle estimate is 2.0-fold (0.31 log units) above the measured one; the measured number falls inside the stated range.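

In this assay the change from phenyl to 4-fluorophenyl gives a 6.0-fold lower number from compound 3 to compound 4 (0.78 log units; beyond the scatter) on the core of compound 3, in the same direction as on the core of compound 1. The size of the step holds across the two cores: the same change on two cores in this assay, a 5.3-fold lower number (0.72 log units; beyond the scatter) from compound 1 to compound 2 and a 6.0-fold lower number (0.78 log units; beyond the scatter) from compound 3 to compound 4, 1.2-fold (0.06 log units) apart, within the scatter of two such steps. This rests on two cores only, so it supports carrying the change between these two but does not show that it would hold on any other core, and it gives no reason for the step.

Going by these compounds, whether chloro, a nitrile or an amine at this place on the phenyl ring would give a step of like size stays open. Also open, on these data alone, is which of the differences between the core of compound 1 and the core of compound 3 bears on growth inhibition.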